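The compounds below may be only part of what the source reports. "The series", "measured", "known", "first", "only" and "open" are said of these compounds alone.

Compound 1, `CCc1ccc(-c2nc3c(c(C)nn3-c3ccccc3)c(-c3ccccc3C#N)c2C#N)cc1`: > 20000 nM
Compound 2, `CCc1ccc(-c2nc3c(c(C)nn3-c3ccccc3)c(-c3ccccc3F)c2C#N)cc1`: > 20000 nM
Compound 3, `Cc1cccc(-c2nc3c(c(C)nn3-c3ccccc3)c(-c3ccccc3O)c2C#N)c1`: > 20000 nM

Of the compounds shown here, three have been tested in an ADME assay on BJ cells (Homo sapiens) for cytotoxicity, with a stated time of 72 h; a lower number here means that less compound is needed, a higher number that more compound is needed for the effect. Compound 1 gives only a limit of the assay, > 20000 nM. Compound 2 likewise gives only a limit, > 20000 nM. The step that the two limits leave unreadable from compound 1 to compound 2 is therefore not readable. Compound 3 also gives only a limit in this assay, > 20000 nM, so its standing among the three can be said only as far as the limit of > 20000 nM in this assay, at which 3 of the 3 values shown sit, reaches: none of the three shows a number, and none can be ordered against another.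

Compound 4, `Cc1nn(-c2ccccc2)c2nc(-c3ccc4c(c3)OCCO4)c(C#N)c(-c3ccccc3O)c12`, differs from compound 3 in one place: 2,3-dihydro-1,4-benzodioxin-6-yl in place of 3-methylphenyl on an aromatic carbon. Among the compounds with values here, no measured step bears on this change. Within the data shown here, the single measured step, from compound 1 to compound 2, concerns a different position and is itself unreadable, so it gives no guide to size or direction. With every value in this assay sitting at the limit, no step beyond the scatter is expected from compound 3 to compound 4, and the most likely outcome is that compound 4 again reaches only the limit.

On that basis compound 4 is estimated at 20000 nM in this assay, with a range from 7000 nM to 50000 nM. The expected step is a number no higher from compound 3 to compound 4 (the limit leaves the size open).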

Compound 4, half-maximal effective concentration: > 20000 nM
Compound 4: a limit, no number; the forecaster's own chance of this, stated with the estimate: 75%; the middle value lies on the limit itself.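

As far as these compounds go, compound 3 and compound 4 both give only a limit in this assay, so no step can be read between them, and the effect of 2,3-dihydro-1,4-benzodioxin-6-yl in place of 3-methylphenyl stays unknown. The compounds shown leave open the concentration at which any of them would give the effect, as all share one reading: the limit of > 20000 nM in this assay, at which 4 of the 4 values shown sit.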